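The source may hold more compounds than are shown below. What is called first, only, known or untested is meant among the compounds shown, and "the series" means these compounds.

Measured so far:
- Compound 1, `Cc1ccc(NC(=O)CSc2nncnc2-c2cccc3ccccc23)c(Br)c1`: 166000 nM
- Compound 2, `Cc1cnc(NC(=O)CSc2nncnc2-c2ccccc2Cl)c(Br)c1`: 144000 nM
- Compound 3, `CCOC(=O)c1ccc(NC(=O)CSc2nncnc2-c2cccc3ccccc23)c(Cl)c1`: 150000 nM

All three were tested in an ADME assay on MT4 cells (Homo sapiens) for cytotoxicity, read by MTT assay (on this read-out lower numbers stand for higher toxicity in this test and higher numbers for lower toxicity in this test), and their numbers sit close together. Compound 2 stands at the low end of the three, but compound 3 and compound 1 both fall within the usual scatter of it, so nothing separates the three compounds on this read-out; they behave alike here.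

Compound 4, `O=C(CSc1nncnc1-c1ccccc1Cl)Nc1ccccc1Cl`, has not yet been measured. It keeps the whole shared core of compound 2 and changes only the group on the amide-type nitrogen: 2-chlorophenyl in place of 3-bromo-5-methylpyridin-2-yl on an amide-type nitrogen.

Among the measured compounds shown here, no step between two measured compounds that differ in one place is available, so there is nothing to lean on directly. What the three measured compounds do show is that three different groups on that amide-type nitrogen all land in the same narrow range. On that basis the step of a 1.0-fold higher number from compound 2 to compound 4 (0.02 log units; within the scatter) is expected to stay within the scatter, in no particular direction. Compound 4 is therefore estimated at 150000 nM, with a likely range from 75000 nM to 300000 nM.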

Compound 4, half-maximal cytotoxic concentration: 90000 nM
Beside the measured number, compound 4's estimate is 1.7-fold (0.22 log units) above it; the range from low to high includes it.
By their numbers in this assay, from the lowest: compounds 4, 2, 3 and 1 (each within the scatter of the next).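

Within this assay the swap of 3-bromo-5-methylpyridin-2-yl for 2-chlorophenyl on the amide-type nitrogen gives a 1.6-fold lower number from compound 2 to compound 4 (0.20 log units; within the scatter) as the first comparison in which only this group differs. With the rest of the molecule held constant, exchanging a six-membered aromatic ring with one hetero atom for a ring of carbon only therefore leaves the read-out within the scatter, and this now rests on a direct pair rather than on a loose comparison of unrelated compounds. Nothing measured here offers an explanation for the size of this step.

Going by these compounds, it remains open whether a non-aromatic group on this nitrogen, such as a butyl chain or a cyclohexyl ring, would stay within the scatter too. The same question stands for a carboxylic acid or an amine carried on the aromatic ring.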